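The source may report more compounds than this note shows. Statements on the series, on what has been measured and on what is new or still open speak of the compounds shown alone.

The three measured compounds share one core. Compound 1 `COC(=O)c1cc(-c2csc(N/N=C/c3cccs3)n2)ccc1OCc1ccccc1` gives 95.5% in a functional assay, read by spectrophotometry, with a stated time of 15 min, tested at 60 ug/mL; on this read-out lower numbers stand for a weaker effect and higher numbers for a stronger effect at the one concentration tested. Compound 2 `Clc1ccc(-c2csc(N/N=C/c3cccs3)n2)cc1` gives 96.1% in this assay, and compound 3 `Fc1ccc(-c2csc(N/N=C/c3cccs3)n2)cc1` gives 94.6% in this assay. Compound 3 carries the lowest of the three numbers, but each of its gaps to the other two lies within the scatter, so no real separation among them can be read. For the measured compounds named here, the one step measured between them, a number 1.5 percentage points lower from compound 2 to compound 3 (within the scatter), stayed within the scatter.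

Compound 4 `Cc1ccc(-c2csc(N/N=C/c3cccs3)n2)cc1` differs from compound 3 in one place: methyl in place of fluoro on an aromatic carbon. Going by the values given here, the measured step that bears on it is a number 1.5 percentage points lower from compound 2 to compound 3 (within the scatter), which exchanged one small group on an aromatic carbon of the same ring and produced nothing beyond the scatter; no measured step brings in a methyl there. Compound 4 is therefore expected to give a number close to that of compound 3. The step of a number 0.6 percentage points lower from compound 3 to compound 4 (within the scatter) that this estimate means is expected to stay within the scatter. The estimate for compound 4 in this assay is 94%, ranging from 87% to 98%.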

Compound 4, a percentage reported as inhibition, at one concentration (the size of the read-out at that concentration, not a potency): 97.6%
Compound 4: the middle estimate sits 3.6 percentage points below what was measured, and the stated range covers the measured number.
By their numbers in this assay, from the lowest: compounds 3, 1, 2 and 4 (each within the scatter of the next).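

Methyl is the first group on this aromatic carbon, para to a large group, that is not a halogen, and the earlier compounds had only compared chloro with fluoro. In this assay, the exchange gives a number 3 percentage points higher from compound 3 to compound 4 (within the scatter) and a number 1.5 percentage points higher from compound 2 to compound 4 (within the scatter) and so separates methyl from neither halogen. Across fluoro, chloro and methyl, which are all small groups, this position therefore shows no change that can be read, and nothing measured here offers a reason for that.

As far as these compounds go, whether an amine, a carboxylic acid or a longer chain at this place would move the number beyond the scatter remains open. Also open, from the compounds shown here alone, is whether these compounds would separate at a lower concentration, since a single concentration gives no potency.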